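This account rests on a few compounds, and the source may have more. Where it says the series, first, only, none or still open, it means among the compounds named here.

Measured in a functional assay on BGC-823 cells (Homo sapiens) for inhibition, read by MTT assay, with a stated time of 72 h; on this read-out lower numbers stand for stronger inhibition and higher numbers for weaker inhibition:

- Compound 1 `Cc1cc(N2CC[C@@H](C)[C@@H](N(C)c3ncnc4[nH]ccc34)C2)n2nc(SCC3CC3)nc2n1`: 36500 nM
- Compound 2 `Cc1cc(N2CC[C@@H](C)[C@@H](N(C)c3ncnc4[nH]ccc34)C2)n2nc(SCc3nc4ccccc4[nH]3)nc2n1`: > 100000 nM, which is a limit and not a number
- Compound 3 `C=CCSc1nc2nc(C)cc(N3CC[C@@H](C)[C@@H](N(C)c4ncnc5[nH]ccc45)C3)n2n1`: 40900 nM

Compound 3 stands level with compound 1, as a 1.1-fold higher number from compound 1 to compound 3 (0.05 log units; within the scatter) shows. Among the compounds with values here, these are the only two true numbers in the set, and both reflect weak inhibition.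

Compound 4 `COc1ccc(CSc2nc3nc(C)cc(N4CC[C@@H](C)[C@@H](N(C)c5ncnc6[nH]ccc56)C4)n3n2)cc1` keeps the shared core and carries 4-methoxyphenyl in place of vinyl on a saturated chain carbon bound to a sulfur.

Two measured changes at this place bear on it. Exchanging cyclopropyl for vinyl made no difference beyond the scatter. The larger 1H-benzimidazol-2-yl group gave an at least 2.7-fold higher number from compound 1 to compound 2 (0.43 log units; beyond the scatter), and returning from it to vinyl gave an at least 2.4-fold lower number from compound 2 to compound 3 (0.38 log units; beyond the scatter). That group differs from 4-methoxyphenyl, so it is only a loose guide. A modest rise in this assay is therefore expected, and the estimated change is a 1.3-fold higher number from compound 3 to compound 4 (0.13 log units; within the scatter). For compound 4 the expected value is 55000 nM, with an estimated range of 20000 nM to 100000 nM.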

Compound 4, half-maximal inhibitory concentration: 69900 nM
Compound 4: middle estimate off by 1.3-fold (0.10 log units), on the low side; the range from low to high includes it.
By their numbers in this assay, from the lowest: compounds 1, 3 and 4 (each within the scatter of the next). At a limit, above all of these: compound 2.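

On a saturated chain carbon bound to a sulfur, a group as big as 4-methoxyphenyl, with its six-membered aromatic ring, gives a number that the scatter does not separate from those of the smaller groups. In this assay, replacing vinyl gives a 1.7-fold higher number from compound 3 to compound 4 (0.23 log units; within the scatter), and replacing cyclopropyl gives a 1.9-fold higher number from compound 1 to compound 4 (0.28 log units; within the scatter). Nor can compound 4 be firmly separated from the benzimidazole compound, given an at least 1.4-fold lower number from compound 2 to compound 4 (0.15 log units; that floor lies within the scatter), and compound 2 itself is held at a limit and not a number: the limit of > 100000 nM in this assay, at which 1 of the 4 values shown sits.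

From the compounds shown here alone, whether an amine, a carboxylic acid or a longer chain on this carbon would give a clearly lower number stays open. Also open, going by these compounds, is whether the 1H-benzimidazol-2-yl and 4-methoxyphenyl groups truly differ here.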